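Aryl substitution on the chain carbon: maximal response notes

The source may hold more compounds than are shown below. What is called first, only, known or untested is meant among the compounds shown, and "the series" means these compounds.

Compound 1 `N=C(NCCCc1c[nH]cn1)NCCC(c1ccccc1)c1ccccn1`: 1
Compound 2 `N=C(NCCCc1c[nH]cn1)NCCC(c1ccc(F)cc1)c1ccccn1`: 1
Compound 3 `N=C(NCCCc1c[nH]cn1)NCCC(c1ccc(C(F)(F)F)cc1)c1ccccn1`: 0.9

In a functional assay on cardiac atrium for agonist activity at histamine H2 receptor (Cavia porcellus) (a higher number here means a larger maximal response, a lower number a smaller maximal response), compound 3 gives 0.9, the lowest of the three numbers, yet its steps to compound 1 and to compound 2 both lie within the scatter. Compound 4 `N=C(NCCCc1c[nH]cn1)NCCC(c1cccc(F)c1)c1ccccn1` differs from compound 3 by 3-fluorophenyl in place of 4-(trifluoromethyl)phenyl on a saturated chain carbon bound to an aromatic carbon and a saturated chain carbon.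

The relevant steps are a number 0.10 lower from compound 1 to compound 3 (within the scatter), a number 0.10 lower from compound 2 to compound 3 (within the scatter) and no change at the digits printed from compound 1 to compound 2 (within the scatter); none moved the maximal response beyond the scatter, whether hydrogen, fluoro or trifluoromethyl occupied the phenyl. Exchanging the 4-(trifluoromethyl)phenyl for a 3-fluorophenyl is therefore expected to give no step beyond the scatter, a number 0.10 higher from compound 3 to compound 4 (within the scatter). Compound 4 is estimated at 1, with a range from 0.9 to 1.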

Compound 4, intrinsic activity: the largest response reached, as a fraction of the reference agonist's: 1
Estimate against measurement, compound 4: no gap at the digits printed; low and high end bracket the measured number.
By their numbers in this assay, from the lowest: compounds 3, 1, 2 and 4 (each within the scatter of the next).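

In this assay, among these compounds, 3-fluorophenyl in place of 4-fluorophenyl gives no change at the digits printed from compound 2 to compound 4 (within the scatter) and so gives a first reading on where the fluoro sits on this phenyl, with no step beyond the scatter. The unsubstituted phenyl gives no change at the digits printed from compound 1 to compound 4 (within the scatter) and the 4-(trifluoromethyl)phenyl gives a number 0.10 higher from compound 3 to compound 4 (within the scatter) and thus all four aryl groups on this saturated chain carbon lie within the scatter of one another. No available evidence bears on why the maximal response holds across these groups.

From the compounds shown here alone, whether an amine or a carboxylic acid on this phenyl would keep the maximal response remains open. Also open, going by these compounds, is whether any group at this carbon moves it beyond the scatter.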